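The source may hold more compounds than are shown below. What is called first, only, known or untested is meant among the compounds shown, and "the series" means these compounds.

Compound 1 `OCc1cn(Cc2cccc(Cl)c2)c2ccccc12` is the reference here; in a functional assay on NCI-H460 cells (Homo sapiens) for cytotoxicity, read by sulforhodamine B assay, with a stated time of 3 days (a higher number here means a weaker inhibitor, a lower number a stronger inhibitor), compound 1 gives 19 nM. Compound 2 `Cc1cccc(Cn2cc(CO)c3ccccc32)c1` differs from compound 1 by methyl in place of chloro on an aromatic carbon, and in this assay compound 2 gives 31 nM; the step is a 1.6-fold higher number from compound 1 to compound 2 (0.21 log units; within the scatter). Compound 3 `OCc1cn(Cc2ccc(Cl)cc2)c2ccc(F)cc12` stands on a different core, and how it differs from compound 1 is not broken down here; in this assay compound 3 gives 30 nM. Compound 4 `Cc1ccc(Cn2cc(CO)c3cc(F)ccc32)cc1` is not yet measured; it differs from compound 3 by methyl in place of chloro on an aromatic carbon. This is the same kind of change as from compound 1 to compound 2, though there the group stands meta to a large group and here para to a large group. Because the matched step a 1.6-fold higher number from compound 1 to compound 2 (0.21 log units; within the scatter) lay within the scatter, compound 4 is expected to shift by about a 1.5-fold higher number from compound 3 to compound 4 (0.18 log units; within the scatter). Compound 4 is therefore estimated at 45 nM in this assay, between 20 nM and 100 nM.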

Compound 4, half-maximal inhibitory concentration: 10 nM
Beside the measured number, compound 4's estimate is 4.5-fold (0.65 log units) above it, and the stated range ends above it.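

In this assay, methyl in place of chloro gives a 3.0-fold lower number from compound 3 to compound 4 (0.48 log units; beyond the scatter), so this change does not carry over from the core of compound 1 to the core of compound 3 as a fixed shift. Going by these compounds alone, the two steps differ by more than the scatter: the same change on two cores in this assay, a 1.6-fold higher number (0.21 log units; within the scatter) from compound 1 to compound 2 and a 3.0-fold lower number (0.48 log units; beyond the scatter) from compound 3 to compound 4, 4.9-fold (0.69 log units) apart, beyond the scatter of two such steps With only two pairs, and the group para to a large group only in the second, these data cannot separate the effect of the core from that of the group's position, and they give no rule for other cores.

Still open, from the compounds shown here alone, is how this change behaves with the position held constant across both cores. Also open, going by these compounds, is how methoxy or trifluoromethyl would compare with methyl and chloro at this place.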